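Pyridyl isomer swap on the biaryl imidazoline series

The source may hold more compounds than are shown below. What is called first, only, known or untested is meant among the compounds shown, and "the series" means these compounds.

Compound 1 `CC(Oc1ccccc1-c1cccnc1)C1=NCCN1` is assayed in a functional assay on CHO cells for agonist activity at Alpha-2B adrenergic receptor (Homo sapiens) (a higher number here means a larger maximal response, a lower number a smaller maximal response), where compound 1 gives 0.5. Compound 2 `CC(Nc1ccccc1-c1ccccc1)C1=NCCN1` gives 0.5 in this assay; compound 1 stands level with compound 2 at the digits shown, the two values sitting within the usual scatter. Compound 3 `CC(Oc1ccccc1-c1ccccn1)C1=NCCN1` has not yet been measured. It differs from compound 1 in one place: pyridin-2-yl in place of pyridin-3-yl on an aromatic carbon. Within the data shown here, no measured pair isolates this change, so no step beyond the scatter is expected in either direction, and for compound 3 the estimated step is no change at the digits printed from compound 1 to compound 3 (within the scatter). Compound 3 is expected to give 0.5, within a range from 0.3 to 0.7.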

Compound 3, intrinsic activity: the largest response reached, as a fraction of the reference agonist's: < 0.3
Compound 3 gave a limit, no number (the forecaster's own chance of this, stated with the estimate: 5%); middle value at least 0.20 away from the limit.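

At this aromatic carbon, the position of the ring nitrogen counts even though the atoms stay the same: in this assay, pyridin-2-yl in place of pyridin-3-yl gives a number at least 0.20 lower from compound 1 to compound 3 (beyond the scatter). Compound 3 gives < 0.3, which is a limit of the assay and not a number. The true size of the step therefore stays unknown, and the reading rests on a limit: the limit of < 0.3 in this assay, at which 1 of the 3 values shown sits.

The compounds shown leave open how pyridin-4-yl would fare at this position. They also leave open whether a methoxy group on the pyridin-2-yl ring would restore the maximal response.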